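The compounds below may be only part of what the source reports. "The series", "measured", "known", "first", "only" and "open" are said of these compounds alone.

Compound 1, `Nc1cc(N)c2nc(-c3ccccc3)c(Oc3ccc(Cl)c(Cl)c3)nc2c1`: in a functional assay on RXF 393 cells (Homo sapiens) for inhibition, read by sulforhodamine B assay, with a stated time of 48 h (a lower number here means that less compound is tolerated, a higher number that more compound is tolerated), compound 1 gives < 100000 nM, which is a limit of the assay and not a number.
Compound 2, `Nc1cc(N)c2nc(-c3ccccc3)c(NCc3ccc(Cl)c(Cl)c3)nc2c1`: compound 2 gives < 100000 nM in this assay, again only a limit.
Compound 3, `Nc1cc(N)c2nc(-c3ccccc3)c(Sc3ccc(F)cc3)nc2c1`: compound 3 gives < 100000 nM in this assay, also a limit.

Where compound 3 stands: only a limit is known for compound 3, and the two further values shown are limits of the same kind, so no order among compounds 1, 2 and 3 can be read from them. Going by the values given here, the single comparison that differs in one place, a step that the two limits leave unreadable from compound 1 to compound 3, is itself unreadable, as both of its ends sit at the limit.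

Compound 4, `Nc1cc(N)c2nc(-c3ccccc3)c(Oc3ccc(F)cc3)nc2c1`, has not yet been measured. It differs from compound 3 as follows: 4-fluorophenoxy in place of (4-fluorophenyl)sulfanyl on an aromatic carbon. Among the compounds with values here, the only measured step that bears on this part of the molecule is a step that the two limits leave unreadable from compound 1 to compound 3, and it gives no size. What the series does show is the limit of < 100000 nM in this assay, at which 3 of the 3 values shown sit, which makes a further limit the most likely outcome for compound 4 as well. Compound 4 is therefore expected to give about 30000 nM in this assay, with a range from 5000 nM to 100000 nM. The step that the limit leaves unreadable from compound 3 to compound 4 is accordingly expected to be no larger than the usual scatter, with a good chance that only a limit is reported.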

Compound 4, concentration lethal to 50% of the cells: < 100000 nM
Compound 4: a limit, no number; the forecaster's own chance of this, stated with the estimate: 70%; the middle value lies beyond the limit too.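

Compound 4 gives < 100000 nM in this assay, a limit and not a number. No new step can be read from compound 3 or compound 1 to compound 4, as the series sits at one limit: the limit of < 100000 nM in this assay, at which 4 of the 4 values shown sit.

The compounds shown leave open how far each lies from that limit, and whether exchanging the sulfur for oxygen changes the read-out at all.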